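Swapping the Benzamide Substituent on a Sulfonate Antagonist

A few compounds are considered here, and "the series" means these few. Any claim that something is new, unique, unknown or untested is made for them only; others in the source may bear on it.

Two compounds are measured in an assay on HEK293 cells for antagonist activity at P2X purinoceptor 7 (Homo sapiens), read by fluorescence, with a stated time of 2 h; a lower number here means a stronger inhibitor, a higher number a weaker inhibitor. Compound 1 `CN(C)c1ccc(C(=O)N2CCC(n3cncc3-c3ccc(OS(=O)(=O)c4cccc(C#N)c4)cc3)CC2)cc1` gives 32 nM. Compound 2 `CS(=O)(=O)c1ccc(C(=O)N2CCC(n3cncc3-c3ccc(OS(=O)(=O)c4cccc(C(=O)NC5CC5)c4)cc3)CC2)cc1` gives 400 nM, the highest of the two numbers; its nearest neighbour is compound 1, whose number is lower by a margin beyond the scatter. Within the data shown here, no single-point step between the two measured compounds exists. Compound 1 and compound 2 differ in more than one place.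

Compound 3 `CN(C)c1ccc(C(=O)N2CCC(n3cncc3-c3ccc(OS(=O)(=O)c4cccc(C(=O)NC5CC5)c4)cc3)CC2)cc1` is compound 2 with the change (dimethylamino in place of methylsulfonyl on an aromatic carbon). Compound 3 thus carries the same benzamide group as compound 1 while keeping the cyclopropyl amide of compound 2. Without a direct step, the expected size rests only on compound 1 standing at 32 nM; a lower number than compound 2 is expected, and the step from compound 2 to compound 3 is estimated at a 3.1-fold lower number from compound 2 to compound 3 (0.49 log units; beyond the scatter). Compound 3 is therefore expected to give about 130 nM, within 40 nM to 450 nM.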

Compound 3, half-maximal inhibitory concentration: 0.49 nM
For compound 3 the middle estimate is 270-fold (2.42 log units) above the measured one; measured number outside the range, below it.
By their numbers in this assay, from the lowest: compound 3; then compound 1; then compound 2.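

Dimethylamino in place of methylsulfonyl on the aromatic carbon para to a large group gives an 820-fold lower number from compound 2 to compound 3 (2.91 log units; beyond the scatter) in this assay with the cyclopropyl amide held fixed, which shows that this position alone carries a large part of the difference, something the first two compounds, differing in more than one place, could not show. The second site matters as well: with dimethylamino held fixed, cyclopropylcarbamoyl in place of cyano gives a 65-fold lower number from compound 1 to compound 3 (1.81 log units; beyond the scatter) in this assay, so each single change lowers the number by a margin beyond the scatter. Nothing in the data shown accounts for the size of either step.

As far as these compounds go, whether a primary amine or a morpholine at this position would match dimethylamino remains open. So does whether the step from methylsulfonyl keeps its size when a nitrile or a carboxylic acid stands at the second site.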